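The compounds below may be only part of what the source reports. "The series", "measured", "known", "first", "only" and "open" are said of these compounds alone.

Compound 1 `COc1ccc(NC(=S)NC2CC(C)(C)Oc3ccc(Br)cc32)cc1`: 40000 nM
Compound 2 `CC1(C)CC(NC(=S)Nc2cccc(C#N)c2)c2cc(Br)ccc2O1`: 6000 nM
Compound 3 `CC1(C)CC(NC(=S)Nc2cccc(C#N)c2)c2cc(F)ccc2O1`: 30000 nM

These three compounds were measured in a functional assay on U-373MG ATCC cells (Homo sapiens) for inhibition, read by MTT assay, with a stated time of 72 h; on this read-out lower numbers stand for stronger inhibition and higher numbers for weaker inhibition. Compound 2 gives the lowest number of the three, and the other two both stand beyond the scatter from it. Compound 4 `CC1(C)CC(NC(=S)Nc2cccc([N+](=O)[O-])c2)c2cc(Br)ccc2O1` differs from compound 2 in a single group: nitro in place of cyano on an aromatic carbon. In short, it carries nitro in place of cyano on an aromatic carbon.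

Among the measured compounds shown here, no measured step makes this exchange. The nearest is a 6.7-fold lower number from compound 1 to compound 2 (0.82 log units; beyond the scatter), which also changes the group-bearing aromatic ring that differs here. The other, a 5.0-fold higher number from compound 2 to compound 3 (0.70 log units; beyond the scatter), alters a different part of the molecule and bears on the question only loosely. Both steps are modest, and neither points to a direction for the new exchange. In this assay, a change no larger than these is therefore expected, most likely none beyond the scatter. The expected change is a 1.2-fold higher number from compound 2 to compound 4 (0.07 log units; within the scatter). For compound 4 the estimated value is 7000 nM, with an expected range from 2500 nM to 20000 nM.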

Compound 4, half-maximal inhibitory concentration: 4000 nM
For compound 4 the middle estimate is 1.8-fold (0.24 log units) above the measured one, within the range that was stated.
By their numbers in this assay, from the lowest: compounds 4 and 2 (each within the scatter of the next); then compounds 3 and 1 (each within the scatter of the next).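

In this assay, replacing cyano with nitro on the aromatic carbon meta to a large group gives a 1.5-fold lower number from compound 2 to compound 4 (0.18 log units; within the scatter), so this exchange leaves the number within the scatter even though nitro has more heavy atoms and hydrogen-bond acceptors than cyano. The earlier step on this ring, from 4-methoxyphenyl to 3-cyanophenyl, changed both the group and its place, whereas this pair holds the place fixed and changes the group alone. No measured evidence here explains why the two groups read alike.

The compounds shown leave open whether an amine or a carboxylic acid in this same place would also stay within the scatter. They also leave open whether nitro would keep this number with fluoro in place of bromo on the core.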